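Exchanging bromo for iodo in compound 2

This account rests on a few compounds, and the source may have more. Where it says the series, first, only, none or still open, it means among the compounds named here.

In a functional assay on MCF7 cells (Homo sapiens) for inhibition (on this read-out lower numbers stand for stronger inhibition and higher numbers for weaker inhibition), compound 1 `COc1ccc(-c2nc3cc(F)ccc3s2)cc1Cl` gives 760 nM, and compound 2 `COc1ccc(-c2nc3cc(F)ccc3s2)cc1Br` gives 850 nM. Within the data shown here, these are the only two numbers so far, and compound 2 stands within the scatter of compound 1, so the pair cannot be ranked. Among the measured compounds shown here, the single measured step is a 1.1-fold higher number from compound 1 to compound 2 (0.05 log units; within the scatter), and it is bromo in place of chloro on an aromatic carbon.

Compound 3 `COc1ccc(-c2nc3cc(F)ccc3s2)cc1I` has not yet been measured in this assay. Its difference from compound 2 is iodo in place of bromo on an aromatic carbon of a six-membered aromatic ring of carbon only, ortho to a methoxy group and meta to a large group. For the measured compounds named here, the one measured step is the same kind of exchange, one halogen for another on an aromatic carbon, and it alone bears on this change. One step cannot establish a trend, but compound 2 differs from compound 1 by only a 1.1-fold higher number from compound 1 to compound 2 (0.05 log units; within the scatter), so no step beyond the scatter is expected in this assay. The expected step is a 1.1-fold higher number from compound 2 to compound 3 (0.02 log units; within the scatter). Compound 3 is expected to give 900 nM, with an estimated range from 450 nM to 1800 nM.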

Compound 3, half-maximal inhibitory concentration: 820 nM
Compound 3: the middle estimate sits 1.1-fold (0.04 log units) above what was measured, within the range that was stated.
By their numbers in this assay, from the lowest: compounds 1, 3 and 2 (each within the scatter of the next).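

Iodo now joins chloro and bromo on this aromatic carbon, ortho to a methoxy group and meta to a large group, and in this assay both new steps (a 1.0-fold lower number from compound 2 to compound 3 (0.02 log units; within the scatter); a 1.1-fold higher number from compound 1 to compound 3 (0.03 log units; within the scatter)) stay within the scatter. Among these compounds, the earlier pair offered only one exchange of one halogen for another, whereas three such exchanges at this place now agree in showing no step beyond the scatter, so compound 1, compound 2 and compound 3 cannot be ranked. No evidence is at hand to explain why these three halogens give numbers that cannot be told apart.

The compounds shown carry only these three halogens at this place, so they leave open whether the read-out would stay in the same range with a group of another kind there, such as a nitrile, an amine or a carboxylic acid. They also leave open whether the halogens would remain interchangeable if the methoxy group were exchanged for a longer chain such as propoxy.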